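Urea-linked anilinoquinazolines: an ester replaces a chloro-trifluoromethyl ring

The compounds below may be only part of what the source reports. "The series", "measured", "known", "first", "only" and "open" are said of these compounds alone.

Measured compounds:
compound 1, `COc1cc(Nc2ncnc3c(NC(=O)Nc4cccc(Oc5ccccc5)c4)cccc23)cc(OC)c1`: 14000 nM
compound 2, `COc1cc(Nc2ncnc3c(NC(=O)Nc4ccc(Cl)c(C(F)(F)F)c4)cccc23)cc(OC)c1`: > 20000 nM

Compound 1 was tested in a functional assay on RT-112 cells (Homo sapiens) for antiproliferative activity, read by MTT assay, with a stated time of 72 h (on this read-out higher numbers stand for weaker inhibition of growth and lower numbers for stronger inhibition of growth), and gives 14000 nM. Compound 2 is a separate case: in this assay compound 2 gives > 20000 nM, which is a limit of the assay rather than a number. Compound 2 thus sits at the limit of > 20000 nM in this assay, at which 1 of the 2 values shown sits. For the measured compounds named here, no step between the two measured compounds is given, so the two values say only that compound 1 yields a number and compound 2 does not.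

Compound 3, `CCOC(=O)c1ccc(NC(=O)Nc2cccc3c(Nc4cc(OC)cc(OC)c4)ncnc23)cc1`, has not yet been measured in this assay. It departs from compound 2 by 4-(ethoxycarbonyl)phenyl in place of 4-chloro-3-(trifluoromethyl)phenyl on an amide-type nitrogen.

Compound 2 is known only as a limit, so the step to compound 3 cannot be anchored. The expectation for compound 3 is a number of the same order as that of compound 1, 14000 nM. The step from compound 2 to compound 3 is expected to be an at least 1.3-fold lower number from compound 2 to compound 3 (0.12 log units; that floor lies within the scatter), or none beyond the scatter. For compound 3 the estimate in this assay is 15000 nM, with a range from 5000 nM to 40000 nM.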

Compound 3, concentration for 50% growth inhibition: 317 nM
The estimate for compound 3 lay 47-fold (1.68 log units) above the measured number; measured number outside the range, below it.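

In this assay the aryl group on the amide-type nitrogen proves to be a place where a single change can matter greatly: 4-(ethoxycarbonyl)phenyl in place of 4-chloro-3-(trifluoromethyl)phenyl gives an at least 63-fold lower number from compound 2 to compound 3 (1.79 log units; beyond the scatter) in a step that lies beyond the scatter. The two groups hold the same count of heavy atoms and each has one six-membered aromatic ring of carbon only, so a step of this size does not go with the heavy-atom count; the entering group differs in carrying an ester with hydrogen-bond acceptors, where the leaving group has none. The step is a floor and not an exact size, since the reading of compound 2 is a limit of the assay: the limit of > 20000 nM in this assay, at which 1 of the 3 values shown sits.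

The compounds shown leave open whether the gain belongs to the ethoxycarbonyl group itself or to the loss of the chlorine and trifluoromethyl substituents. They also leave open how a carboxylic acid, a primary amide or a longer ester such as butoxycarbonyl would read in this assay in that place.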